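Removing the para chloro substituent from a thiazoline sulfone

This account rests on a few compounds, and the source may have more. Where it says the series, first, only, none or still open, it means among the compounds named here.

Measured so far:
compound 1 `O=S(=O)(CC1=NCCO1)c1n[nH]cc1-c1ccccc1` gives 58.5%
compound 2 `O=S(=O)(CC1=NCCS1)c1n[nH]cc1-c1ccc(Cl)cc1` gives "not active" (no number reported)

In a functional assay, tested at 100 ug/mL (on this read-out lower numbers stand for a weaker effect and higher numbers for a stronger effect at the one concentration tested), compound 1 `O=S(=O)(CC1=NCCO1)c1n[nH]cc1-c1ccccc1` gives 58.5%. Compound 2 `O=S(=O)(CC1=NCCS1)c1n[nH]cc1-c1ccc(Cl)cc1`, which carries a thiazoline in place of the oxazoline and a 4-chlorophenyl on the shared core, is reported in this assay only as "not active" (no number reported), so no single number stands for it and its place on the scale cannot be fixed more closely than that. Compound 3 `O=S(=O)(CC1=NCCS1)c1n[nH]cc1-c1ccccc1` has not yet been tested. It differs from compound 2 by hydrogen in place of chloro on an aromatic carbon. Among the measured compounds shown here, the step from compound 2 to compound 3 cannot be sized from the two values, since compound 2 has no number; the only guidance is that compound 1, which also bears the plain phenyl, shows activity in this assay. Compound 3 is therefore expected to give 30% in this assay, with a range from 5% to 60%.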

Compound 3, a percentage reported as activity, at one concentration (the size of the read-out at that concentration, not a potency): "not active" (no number reported)
For compound 3 the study gives words and no number; there is nothing to compare the estimate with.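

In this assay compound 2 and compound 3 are both reported in words without a number, so no step can be read between them. No measured evidence bears on this result. The compounds shown leave open whether going from 4-chlorophenyl to phenyl changes this read-out at all.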